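Swapping isopropyl for 4-chlorophenyl on the ring nitrogen

This account rests on a few compounds, and the source may have more. Where it says the series, first, only, none or still open, it means among the compounds named here.

- compound 1 `O=C1COc2ccc(-c3cccc(NS(=O)(=O)c4ccc(F)cc4)c3)cc2N1` gives 18300 nM
- compound 2 `CC(C)N1C(=O)COc2ccc(-c3cccc(NS(=O)(=O)c4ccc(F)cc4)c3)cc21` gives 26000 nM

Both values come from a functional assay on MCF7 cells (Homo sapiens) for antiproliferative activity, read by MTT assay, with a stated time of 72 h (on this read-out higher numbers stand for weaker inhibition and lower numbers for stronger inhibition), and compound 2 sits within the usual scatter of compound 1, so neither can be ranked above the other. Still unmeasured is compound 3 `O=C1COc2ccc(-c3cccc(NS(=O)(=O)c4ccc(F)cc4)c3)cc2N1c1ccc(Cl)cc1` with 4-chlorophenyl in place of isopropyl on an amide-type nitrogen in a ring, as counted in 4-chlorophenyl in place of isopropyl on an amide-type nitrogen in a ring and otherwise unchanged. Going by the values given here, one measured step bears on this, isopropyl in place of hydrogen on that same nitrogen, and it shows a 1.4-fold higher number from compound 1 to compound 2 (0.15 log units; within the scatter) in this assay and so gives no sign yet that this nitrogen responds to what it carries. Among the compounds with values here, no compound with an aromatic ring on this nitrogen has been measured, so the forecast stays loose. From the compounds shown here alone, no step beyond the scatter is therefore expected in this assay and the direction stays open. The expected change is a 1.2-fold lower number from compound 2 to compound 3 (0.07 log units; within the scatter) as an estimate only. For compound 3 the expected value is 22000 nM with 8000 nM to 55000 nM as the estimated range.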

Compound 3, half-maximal inhibitory concentration: 39800 nM
Estimate against measurement, compound 3: 1.8-fold (0.26 log units) below; measured number inside the range.
By their numbers in this assay, from the lowest: compounds 1, 2 and 3 (each within the scatter of the next, the first and the last beyond it).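

In this assay this ring nitrogen shows its first step beyond the scatter: 4-chlorophenyl in place of hydrogen gives a 2.2-fold higher number from compound 1 to compound 3 (0.34 log units; beyond the scatter) and so modestly weaker inhibition, not stronger. Measured against isopropyl, the same aromatic group gives a 1.5-fold higher number from compound 2 to compound 3 (0.18 log units; within the scatter) and so cannot be ranked apart from it. The nitrogen therefore shows some response to what it carries, but only when the group is compared with plain hydrogen, and no available measurement offers a reason for this step.

From the compounds shown here alone, it remains open whether an amine, a carboxylic acid or a longer chain on this nitrogen would shift the number in either direction. Going by these compounds, it is equally open whether a phenyl ring without the chlorine would behave like 4-chlorophenyl.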